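The source may hold more compounds than are shown below. What is called first, only, known or untested is meant among the compounds shown, and "the series" means these compounds.

Among the compounds with values here, in an assay on LtK cells with ATP-sensitive inward rectifier potassium channel 11 (Homo sapiens) as the target (on this read-out higher numbers stand for an effect only at larger amounts of compound and lower numbers for an effect already at smaller amounts), compound 2 `O=C(CCc1ccccc1)Nc1c(C(O)(C(F)(F)F)C(F)(F)F)ccc2ccccc12` gives 1750 nM, the highest of the two numbers measured so far. Within the data shown here, compound 1 `CCC(=O)Nc1c(C(O)(C(F)(F)F)C(F)(F)F)ccc2ccccc12` gives 15 nM, and the one measured step runs a 120-fold higher number from compound 1 to compound 2 (2.07 log units; beyond the scatter), brought about by phenyl in place of hydrogen on a saturated chain carbon, two bonds along the chain from a carbonyl carbon. Compound 3 `COc1cccc(C(=O)Nc2c(C(O)(C(F)(F)F)C(F)(F)F)ccc3ccccc23)c1` differs from compound 2 in that (3-methoxyphenyl in place of phenethyl on a carbonyl carbon). Among the measured compounds shown here, no measured pair mirrors an aromatic ring set directly on the carbonyl carbon, so the step from compound 1 to compound 2 bears on it only loosely: it shows that a larger group on the amide side raised the number greatly. Compound 3 keeps an aromatic ring there but is shorter, so a number between the two measured ones seems most plausible, with wide uncertainty. For compound 3 the estimate is 400 nM, in a range from 40 nM to 4000 nM. The expected step is a 4.4-fold lower number from compound 2 to compound 3 (0.64 log units; beyond the scatter).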

Compound 3, half-maximal effective concentration: 185 nM
For compound 3 the middle estimate is 2.2-fold (0.33 log units) above the measured one; low and high end bracket the measured number.
By their numbers in this assay, from the lowest: compound 1; then compound 3; then compound 2.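

In this assay, the change at this carbonyl carbon gives a 9.5-fold lower number from compound 2 to compound 3 (0.98 log units; beyond the scatter) when 3-methoxyphenyl replaces phenethyl, so a group carrying an aromatic ring need not raise the number as far as phenethyl does. The ring is not neutral either: setting 3-methoxyphenyl in place of ethyl gives a 12-fold higher number from compound 1 to compound 3 (1.09 log units; beyond the scatter) and leaves ethyl with the lowest number of the three. Across these compounds, the size of the rise from ethyl therefore depends on which ring-bearing group is attached, even though the two groups have the same number of heavy atoms.

Still open, going by these compounds, is whether the methoxy group or the ring sitting directly on the carbonyl carbon matters more, which a plain phenyl or a benzyl group would help separate, and how a longer alkyl chain or an amine would compare. No measured evidence on hand accounts for these differences.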